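A Chloro-Methoxyphenyl Analogue Tested on Liver Microsomes

The source may hold more compounds than are shown below. What is called first, only, known or untested is meant among the compounds shown, and "the series" means these compounds.

Compound 3, `Nc1nc(NCCNc2ncc(-c3ncc[nH]3)c(-c3cc(F)ccc3F)n2)ccc1[N+](=O)[O-]`, is one of three close relatives examined so far in an ADME assay on microsomes from liver (Rattus norvegicus) for metabolic stability; a lower number here means that the compound disappears faster, a higher number that the compound lasts longer. In this assay compound 3 gives > 0.5 h, which is a limit of the assay and not a number. Compound 1, `Nc1nc(NCCNc2ncc(-c3ncc[nH]3)c(-c3ccc(C(F)(F)F)cc3)n2)ccc1[N+](=O)[O-]`, gives > 0.5 h in this assay, again a limit. Compound 2, `Nc1nc(NCCNc2ncc(-c3ncc[nH]3)c(-c3ccc(F)cc3F)n2)ccc1[N+](=O)[O-]`, gives > 0.5 h in this assay, also a limit. Because of the limit of > 0.5 h in this assay, at which 3 of the 3 values shown sit, the steps among the three cannot be read: a step that the two limits leave unreadable from compound 1 to compound 2, a step that the two limits leave unreadable from compound 1 to compound 3 and a step that the two limits leave unreadable from compound 2 to compound 3. Compound 4, `COc1cc(Cl)ccc1-c1nc(NCCNc2ccc([N+](=O)[O-])c(N)n2)ncc1-c1ncc[nH]1`, differs from compound 3 in one place: 4-chloro-2-methoxyphenyl in place of 2,5-difluorophenyl on an aromatic carbon. Among the measured compounds shown here, no measured step bears readably on this change. The three values together show only that each of the aryl groups tried at this position has kept the half-life at the limit, and nothing suggests compound 4 will break away from that. Compound 4 is therefore expected to behave similarly, with a step that the limit leaves unreadable from compound 3 to compound 4 giving an estimated half-life of 1 h, between 0.4 h and 3 h.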

Compound 4, half-life: > 0.5 h
Compound 4 ended at the assay's limit; the forecaster's own chance of this, stated with the estimate: 70%; the middle value is on the limit's open side.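

In this assay compound 4 gives > 0.5 h, which is a limit of the assay and not a number. Its steps from compound 1, compound 2 and compound 3 therefore cannot be read: the limit of > 0.5 h in this assay, at which 4 of the 4 values shown sit. As far as these compounds go, how long each of these four compounds actually lasts, and whether their aryl groups differ at all, stays open.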